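The source may hold more compounds than are shown below. What is called first, only, known or untested is meant among the compounds shown, and "the series" means these compounds.

Series notes. Going by the values given here, compound 1 `CC(C)(C)c1cc(NC(=O)[C@@H]2CCCCN2C(=O)c2ccccc2)no1` is the reference point; in a physicochemical assay for solubility, read by HPLC, at pH 6.8 (a higher number here means a more soluble compound, a lower number a less soluble compound), compound 1 gives 0.9 ug/mL, the lowest of the three numbers measured so far. Compound 2 `CC(C)(C)c1cc(NC(=O)[C@@H]2CCCCN2C(=O)C2CCS(=O)(=O)CC2)no1` gives 67 ug/mL, and compound 3 `CC(C)(C)c1cc(NC(=O)[C@@H]2CCCCN2C(=O)CC2CCOCC2)no1` gives 52 ug/mL; between these two the difference is small, a 1.3-fold lower number from compound 2 to compound 3 (0.11 log units; within the scatter). Both replace the phenyl on the carbonyl carbon, with large upward steps: a 74-fold higher number from compound 1 to compound 2 (1.87 log units; beyond the scatter) and a 58-fold higher number from compound 1 to compound 3 (1.76 log units; beyond the scatter). Compound 4 `CC(=O)N1CCN(C(=O)N2CCCC[C@H]2C(=O)Nc2cc(C(C)(C)C)on2)CC1` changes the same position: 4-acetylpiperazin-1-yl in place of phenyl on a carbonyl carbon. The two measured exchanges at this carbonyl carbon are the ones that bear on it, and both were large and upward, so a large upward step is expected for compound 4 as well, a 56-fold higher number from compound 1 to compound 4 (1.74 log units; beyond the scatter). Compound 4 is accordingly expected to give about 50 ug/mL, with an estimated range of 15 ug/mL to 150 ug/mL.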

Compound 4, solubility: 62 ug/mL
Compound 4: the middle estimate sits 1.2-fold (0.09 log units) below what was measured; low and high end bracket the measured number.
By their numbers in this assay, from the lowest: compound 1; then compounds 3, 4 and 2 (each within the scatter of the next).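

A third non-aromatic group at the carbonyl carbon, 4-acetylpiperazin-1-yl, again gives a large upward step from phenyl (a 69-fold higher number from compound 1 to compound 4 (1.84 log units; beyond the scatter)), so in this assay all three exchanges shown go the same way and none goes against it. Unlike the two earlier groups, it is named as joined through its ring nitrogen, yet the result stays level with both (a 1.2-fold higher number from compound 3 to compound 4 (0.08 log units; within the scatter); a 1.1-fold lower number from compound 2 to compound 4 (0.03 log units; within the scatter)). No measurement here accounts for these steps.

From the compounds shown here alone, it remains open whether a carboxylic acid or a free piperazine amine at this carbonyl carbon would stay level with compounds 2, 3 and 4 or depart from them. Going by these compounds, a pyridine ring in place of phenyl is equally open.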